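This account rests on a few compounds, and the source may have more. Where it says the series, first, only, none or still open, it means among the compounds named here.

Of the compounds shown here, three have been measured in a functional assay on HeLa cells (Homo sapiens) for cytotoxicity, in the presence of a further agent that is not named here; a higher number here means a weaker inhibitor, a lower number a stronger inhibitor. Compound 1 (`Clc1ccc(-c2cc(-c3ccc(Cl)o3)cc(-c3ccsc3)n2)cc1`) gives 8410 nM, compound 2 (`Cc1ccc(-c2cc(-c3ccoc3)cc(-c3ccsc3)n2)cc1`) gives 1470 nM and compound 3 (`Clc1ccc(-c2cc(-c3ccoc3)cc(-c3cccs3)n2)cc1`) gives 5530 nM. Compound 3 thus lies within the scatter of compound 1, and its number is beyond the scatter above that of compound 2. Compound 4 (`Clc1ccc(-c2cc(-c3ccoc3)cc(-c3ccsc3)n2)cc1`) has thiophen-3-yl in place of thiophen-2-yl on an aromatic carbon. Among the compounds with values here, no measured pair shows this change alone. In this assay a slight shift to a lower number, within the scatter, is expected, since compound 2, which also carries thiophen-3-yl, gives 1470 nM. Against this, compound 1 carries the same group and gives 8410 nM. The estimated change is a 1.5-fold lower number from compound 3 to compound 4 (0.16 log units; within the scatter). Compound 4 is expected to give 3800 nM, within an estimated range of 1700 nM to 8500 nM.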

Compound 4, half-maximal inhibitory concentration: 4140 nM
Compound 4: middle estimate off by 1.1-fold (0.04 log units), on the low side, and the stated range covers the measured number.
By their numbers in this assay, from the lowest: compound 2; then compounds 4, 3 and 1 (each within the scatter of the next, the first and the last beyond it).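

Swapping thiophen-2-yl for thiophen-3-yl next to the ring nitrogen gives a 1.3-fold lower number from compound 3 to compound 4 (0.13 log units; within the scatter) in this assay and so does not separate these two attachments with this substitution pattern. Beyond the scatter, chloro in place of methyl gives a 2.8-fold higher number from compound 2 to compound 4 (0.45 log units; beyond the scatter) and furan-3-yl in place of 5-chlorofuran-2-yl gives a 2.0-fold lower number from compound 1 to compound 4 (0.31 log units; beyond the scatter) on the same core. Nothing available explains any of these steps. The compounds shown leave open whether the thiophene swap reads the same alongside methyl or 5-chlorofuran-2-yl. They also leave open how an amine or a carboxylic acid would fare at the thiophene position.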